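The compounds below may be only part of what the source reports. "The series", "measured", "known", "first", "only" and "open" are said of these compounds alone.

Compound 1 `COc1cccc(/C=C/C[C@H]2C[C@@H]([C@@H](O)c3ccccc3)CO[C@@H]2c2ccccc2)c1` is the reference point of the series. In a functional assay on HeLa cells (Homo sapiens) for cytotoxicity, read by WST assay, with a stated time of 48 h (on this read-out lower numbers stand for stronger inhibition and higher numbers for weaker inhibition), compound 1 gives 10900 nM, the only number shown across the set. Compound 2 `COc1ccc(/C=C/C[C@H]2C[C@@H]([C@@H](OC)c3ccc(OC)c(OC)c3)CO[C@@H]2c2ccc(OC)c(OC)c2)cc1OC` does not give a number: in this assay compound 2 gives > 100000 nM, which is a limit of the assay (the limit of > 100000 nM in this assay, at which 1 of the 2 values shown sits). Compound 3 `O[C@@H](c1ccccc1)[C@H]1CO[C@H](c2ccccc2)[C@@H](C/C=C/c2cccnc2)C1` is not yet measured. It differs from compound 1 by pyridin-3-yl in place of 3-methoxyphenyl on a double-bonded chain carbon bound to a double-bonded chain carbon. Within the data shown here, no measured step matches this change, so nothing beyond the usual scatter is expected. The expected step is a 1.1-fold higher number from compound 1 to compound 3 (0.04 log units; within the scatter), none beyond scatter. Compound 3 is accordingly estimated at 12000 nM, within 4000 nM to 40000 nM.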

Compound 3, half-maximal inhibitory concentration: > 100000 nM
Compound 3 gave a limit, no number; the forecaster's own chance of this, stated with the estimate: 10%; middle value at least 8.3-fold (0.92 log units) away from the limit.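

Among these compounds, this is the first single-place step: in this assay, pyridin-3-yl in place of 3-methoxyphenyl on a double-bonded chain carbon bound to a double-bonded chain carbon gives an at least 9.1-fold higher number from compound 1 to compound 3 (0.96 log units; beyond the scatter), so the read-out is sensitive to this change at this position. As far as these compounds go, for compound 3, > 100000 nM is a limit of the assay and not a number, so the full size of the step stays unknown. Compound 3 also sits at the top of the measurable range: the limit of > 100000 nM in this assay, at which 2 of the 3 values shown sit.

The step removes the methoxy group and brings in the ring nitrogen together, and the compounds shown do not separate the two. From the compounds shown here alone, how a plain phenyl or an aminophenyl at this place would read remains open.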